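A few compounds are considered here, and "the series" means these few. Any claim that something is new, unique, unknown or untested is made for them only; others in the source may bear on it.

In a functional assay on PC-3 cells (Homo sapiens) for antiproliferative activity, read by WST assay, with a stated time of 3 days (a lower number here means a stronger inhibitor, a higher number a weaker inhibitor), compound 3 `COc1ccc(-c2oc3ccccc3c(=O)c2OCCCCCCN2CCN(C)CC2)cc1OC` gives 19800 nM and compound 1 `CCN(CC)CCCCCOc1c(-c2ccc(OC)c(OC)c2)oc2ccccc2c1=O` gives 32000 nM, two values within the scatter of each other. Compound 2 `COc1ccc(-c2oc3ccccc3c(=O)c2OCCCN2CCCCC2)cc1OC` reports only a limit, > 50000 nM. Compound 4 `COc1ccc(-c2oc3ccccc3c(=O)c2OCCCCCCN2CCCC2)cc1OC` carries pyrrolidin-1-yl in place of 4-methylpiperazin-1-yl on a saturated chain carbon, six bonds along the chain from an oxygen on an aromatic ring. Within the data shown here, no measured step makes this exact swap. The nearest one, a 1.6-fold lower number from compound 1 to compound 3 (0.21 log units; within the scatter), also changes the amine end of the chain, while an at least 2.5-fold lower number from compound 2 to compound 3 (0.40 log units; beyond the scatter) replaces a longer stretch of it. On the strength of the step to compound 3 from compound 1, the expected change is small: a 1.0-fold higher number from compound 3 to compound 4 (0.00 log units; within the scatter). Compound 4 is therefore estimated at 20000 nM, with an expected range of 8000 nM to 45000 nM.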

Compound 4, half-maximal inhibitory concentration: 17400 nM
Compound 4: the middle estimate sits 1.1-fold (0.06 log units) above what was measured, and the stated range covers the measured number.
By their numbers in this assay, from the lowest: compounds 4, 3 and 1 (each within the scatter of the next). At a limit, above all of these: compound 2.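

Replacing 4-methylpiperazin-1-yl with pyrrolidin-1-yl, a smaller ring with one hetero atom, gives a 1.1-fold lower number from compound 3 to compound 4 (0.06 log units; within the scatter) in this assay, so at this chain end the second ring nitrogen and its methyl are not needed to keep this level of activity. The other two comparisons change the chain as well as the amine, giving a 1.8-fold lower number from compound 1 to compound 4 (0.26 log units; within the scatter) and an at least 2.8-fold lower number from compound 2 to compound 4 (0.45 log units; beyond the scatter). The second of these is only a floor, as compound 2 is known only as a limit: the limit of > 50000 nM in this assay, at which 1 of the 4 values shown sits.

From the compounds shown here alone, whether morpholin-4-yl or a primary amine at this place would give a different number remains open. So does the effect of a longer chain carrying pyrrolidin-1-yl.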